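The source may report more compounds than this note shows. Statements on the series, on what has been measured and on what is new or still open speak of the compounds shown alone.

Measured in a functional assay on U-937 cells (Homo sapiens) for inhibition, read by calcium flux; a lower number here means a stronger inhibitor, a higher number a weaker inhibitor:
Compound 1 (`Cn1cc(Cc2ccccc2)nc1N`): > 100000 nM (a limit of the assay, not a number)
Compound 2 (`COc1cccc(Cc2nc(N)n(C)c2Cc2ccccc2)c1`): 40000 nM
Compound 3 (`Nc1nc(Cc2ccccc2)c(Cc2ccccc2)[nH]1`): 13000 nM

Compound 3 has the lowest number of this small set, and compound 2 at 40000 nM lies higher by more than the usual scatter. Compound 4 (`Cc1[nH]c(N)nc1Cc1ccccc1`) differs from compound 3 by hydrogen in place of phenyl on a saturated chain carbon bound to an aromatic carbon. Among the measured compounds shown here, no measured pair isolates this change, so its size can only be judged loosely. Compound 1 also lacks a second phenyl and stands at the limit of > 100000 nM in this assay. A rise in the number beyond the scatter, meaning a weaker inhibitor, is therefore expected. The expected change is a 4.6-fold higher number from compound 3 to compound 4 (0.66 log units; beyond the scatter) in size. For compound 4, 60000 nM is the estimate, and 20000 nM to 150000 nM is the expected range.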

Compound 4, half-maximal inhibitory concentration: > 100000 nM
Compound 4 gave a limit, no number (the forecaster's own chance of this, stated with the estimate: 40%); at least 1.6-fold (0.22 log units) between middle value and limit.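

In this assay, putting hydrogen in place of phenyl on a saturated chain carbon bound to an aromatic carbon gives an at least 7.6-fold higher number from compound 3 to compound 4 (0.88 log units; beyond the scatter), the first direct measure of this change. This phenyl therefore counts for inhibition in this pair, as the step lies beyond the usual scatter. Compound 4 gives a limit and not a number, so the step shows only a minimum size: the limit of > 100000 nM in this assay, at which 2 of the 4 values shown sit.

From the compounds shown here alone, whether a cyclohexyl ring or a shorter group such as a hydroxyl on that carbon could stand in for the phenyl remains open.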